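Removing the fluoro from compound 2: what to expect

This account rests on a few compounds, and the source may have more. Where it says the series, first, only, none or still open, it means among the compounds named here.

Compound 1 `Cc1ncc(CO)c2c(Nc3ccccc3)c(NCc3ccccc3)oc12`: 1680 nM
Compound 2 `CCCCCNc1oc2c(C)ncc(CO)c2c1Nc1cccc(F)c1`: 370 nM

Both compounds were tested in a functional assay on HEK293 cells for agonist activity at Toll-like receptor 8 (Homo sapiens), read by reporter gene assay; a lower number here means that less compound is needed, a higher number that more compound is needed for the effect. Of the two numbers in hand, compound 2 has the lower one; its nearest neighbour is compound 1, whose number is higher by a gap that lies beyond the usual scatter of this assay. Compound 1 and compound 2 differ in more than one place, so no single change can be read from that pair.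

Compound 3 `CCCCCNc1oc2c(C)ncc(CO)c2c1Nc1ccccc1` has not yet been measured. It differs from compound 2 in one place only: hydrogen in place of fluoro on an aromatic carbon. The fluoro sits on the six-membered aromatic ring that carries the anilino nitrogen, meta to a large group, and compound 3 carries a hydrogen there instead. Among the compounds with values here, no measured pair in this set isolates such a change, so there is no step to lean on. With nothing else in the structure altered, the expected step from compound 2 to compound 3 is a 1.5-fold higher number from compound 2 to compound 3 (0.17 log units; within the scatter), a small shift towards a somewhat higher number, within the scatter of this assay. Compound 3 is therefore estimated at 550 nM, with a range from 200 nM to 1500 nM.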

Compound 3, half-maximal effective concentration: 2250 nM
For compound 3 the middle estimate is 4.1-fold (0.61 log units) below the measured one; the whole stated range lies below it.
By their numbers in this assay, from the lowest: compound 2; then compounds 1 and 3 (each within the scatter of the next).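

In this assay the step of a 6.1-fold higher number from compound 2 to compound 3 (0.78 log units; beyond the scatter) lies beyond the scatter, and since 3-fluorophenyl to phenyl is the only difference between these two structures, this single fluoro on an aromatic carbon, meta to a large group, clearly matters on this core: with hydrogen in its place, more compound is needed for the effect. The step of a 1.3-fold higher number from compound 1 to compound 3 (0.13 log units; within the scatter) lies within the scatter, so butyl in place of phenyl on the saturated chain carbon bound to a nitrogen does not separate these two compounds, and with the phenyl ring unsubstituted, this chain change shows no measurable effect in this assay. Nothing available here explains why the fluoro has this effect.

Going by these compounds, whether a chloro, a methoxy or a nitrile on that same aromatic carbon would match the fluoro remains open, as does the effect of a fluoro on another carbon of that ring. On these data alone, it is also open whether adding the fluoro to compound 1 would give a step of similar size, which would show if its effect holds with the phenyl-bearing chain.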